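A few compounds are considered here, and "the series" means these few. Any claim that something is new, unique, unknown or untested is made for them only; others in the source may bear on it.

Compound 1 `COc1cccc(/C=C/C(=O)c2ccccc2NC(=O)NS(=O)(=O)c2ccc(C)cc2)c1` and compound 2 `COc1ccc(/C=C/C(=O)c2ccccc2NC(=O)NS(=O)(=O)c2ccc(C)cc2)c(OC)c1` were both tested in an ADME assay on the whole organism for cytotoxicity, with Artemia salina as the target, with a stated time of 24 h; on this read-out higher numbers stand for an effect only at larger amounts of compound and lower numbers for an effect already at smaller amounts. Compound 1 gives 23.2 ug/mL. Compound 2 gives 16 ug/mL, and the step of a 1.5-fold lower number from compound 1 to compound 2 (0.16 log units; within the scatter) places the two within the scatter of each other, so neither stands apart. Compound 3 `CCc1cc(/C=C/C(=O)c2ccccc2NC(=O)NS(=O)(=O)c2ccc(C)cc2)cc(OC)c1OC` has not been measured. It differs from compound 2 by 3-ethyl-4,5-dimethoxyphenyl in place of 2,4-dimethoxyphenyl on a double-bonded chain carbon bound to a double-bonded chain carbon. Within the data shown here, only the step from compound 1 to compound 2 bears on this change, and it lay within the scatter, so no step beyond the scatter is expected in this assay. For compound 3 the expected value is 16 ug/mL, with a range from 8 ug/mL to 32 ug/mL, which means an expected step of no change at the digits printed from compound 2 to compound 3 (within the scatter).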

Compound 3, concentration for half-maximal effect: 19.2 ug/mL
Compound 3: middle estimate off by 1.2-fold (0.08 log units), on the low side; low and high end bracket the measured number.
By their numbers in this assay, from the lowest: compounds 2, 3 and 1 (each within the scatter of the next).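

In this assay the position on a double-bonded chain carbon bound to a double-bonded chain carbon takes 3-ethyl-4,5-dimethoxyphenyl with no step beyond the scatter, either against 2,4-dimethoxyphenyl (a 1.2-fold higher number from compound 2 to compound 3 (0.08 log units; within the scatter)) or against 3-methoxyphenyl (a 1.2-fold lower number from compound 1 to compound 3 (0.08 log units; within the scatter)). The three substituted phenyl groups shown therefore cannot be told apart on this read-out, even with an ethyl group on the ring. No measurement at hand offers an explanation for this flat result.

On these data alone, whether the position stays this flat with an amine or a carboxylic acid on the ring remains open, as does the effect of a longer chain in place of the ethyl group.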